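This account rests on a few compounds, and the source may have more. Where it says the series, first, only, none or still open, it means among the compounds named here.

Measured compounds in an ADME assay on microsomes from liver (Rattus norvegicus, strain Sprague-Dawley) for metabolic stability, read by HPLC, using NADPH, with stated times of 5 min and 60 min, tested at 10 uM; on this read-out higher numbers stand for a longer-lived compound and lower numbers for a shorter-lived compound:
compound 1, `CC(C)(C)c1ccc(C(=O)NCc2ccc(NS(=O)(=O)C3CC3)cc2Cl)cc1`, 0.55 h
compound 2, `CS(=O)(=O)Nc1ccc(CNC(=O)c2ccc(N3CCCC3)cc2)c(Cl)c1`, 1.28 h

Of the compounds shown here, two have been measured in this assay. Compound 1 gives 0.55 h, and compound 2 gives 1.28 h. Compound 2 holds the higher of the two numbers; its nearest neighbour is compound 1, whose number is lower by a gap that lies beyond the usual scatter of repeated measurements. Among the compounds with values here, no pair of the measured compounds differs in only one place, so no single-change step can be read from them.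

Compound 3, `CS(=O)(=O)Nc1ccc(CNC(=O)c2ccc(C(F)(F)C(F)(F)F)cc2)c(Cl)c1`, has not yet been measured in this assay. It differs from compound 2 in one place: 1,1,2,2,2-pentafluoroethyl in place of pyrrolidin-1-yl on an aromatic carbon. Within the data shown here, no measured pair shows the effect of this change, so any expectation rests on compound 2 alone. On that basis a small step is expected, toward a longer-lived compound, though it may not exceed the scatter: the estimated step is a 1.3-fold higher number from compound 2 to compound 3 (0.10 log units; within the scatter). Compound 3 is accordingly expected to give about 1.6 h in this assay, within a range from 0.7 h to 3.5 h.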

Compound 3, half-life: 1.6 h
Estimate against measurement, compound 3: no gap at the digits printed; measured number inside the range.
By their numbers in this assay, from the lowest: compound 1; then compounds 2 and 3 (each within the scatter of the next).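

In this assay, 1,1,2,2,2-pentafluoroethyl in place of pyrrolidin-1-yl on an aromatic carbon, para to a large group, gives a 1.3-fold higher number from compound 2 to compound 3 (0.10 log units; within the scatter), the first single-change step available in this set. It shows that, between these two compounds, a five-membered non-aromatic ring with one hetero atom and one hydrogen-bond acceptor can give way to a group with no ring and no hydrogen-bond acceptor without a step beyond the scatter of the half-life read-out. The measurements shown offer nothing that would account for this outcome or tie it to any property of either group.

As far as these compounds go, whether this position stays as tolerant with other groups, such as a dimethylamino group, a carboxylic acid or a longer alkyl chain, remains open, as does whether the same change would give a similar step on a different core. Steps involving compound 1 cannot be read, as it differs from compound 2 and compound 3 in more than one place, so the part played by its own groups is also unresolved.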